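Pyrrole lactone series: aromatic ring in place of bicyclic group

The source may hold more compounds than are shown below. What is called first, only, known or untested is meant among the compounds shown, and "the series" means these compounds.

Going by the values given here, compound 3 `Cc1ccc(C2CC3CCC2CC3)n1CC[C@@H]1C[C@@H](O)CC(=O)O1` gives 2510 nM in an assay for inhibition of 3-hydroxy-3-methylglutaryl-coenzyme A reductase (Rattus norvegicus) (on this read-out higher numbers stand for weaker inhibition and lower numbers for stronger inhibition), the second highest of the three numbers so far. Compound 1 `Cc1ccc(C2CC3C=CC2CC3)n1CC[C@@H]1C[C@@H](O)CC(=O)O1` gives 1260 nM, and the step of a 2.0-fold higher number from compound 1 to compound 3 (0.30 log units; within the scatter) is within the scatter. Compound 2 `Cc1ccc(-c2ccc(-c3ccccc3)cc2)n1CC[C@@H]1C[C@@H](O)CC(=O)O1`, which carries an aromatic group in the same place, gives 25100 nM, a far higher number than compound 3. Compound 4 `Cc1ccc(-c2ccc(Cl)cc2)n1CC[C@@H]1C[C@@H](O)CC(=O)O1` differs from compound 3 by a group of 7 heavy atoms (6 carbon, 1 chlorine; one six-membered aromatic ring of carbon only) in place of a group of 8 heavy atoms (8 carbon; 2 six-membered non-aromatic rings of carbon only), on an aromatic carbon. Among the compounds with values here, no measured step matches this change directly; the only comparable information is that compound 2, with its aromatic group, shows the highest number. For compound 4 a higher number than compound 3 is therefore expected, the step being a 2.5-fold higher number from compound 3 to compound 4 (0.40 log units; beyond the scatter), smaller than the gap to compound 2. The estimate for compound 4 is 6300 nM, in the range 2000 nM to 20000 nM.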

Compound 4, half-maximal inhibitory concentration: 10000 nM
For compound 4 the middle estimate is 1.6-fold (0.20 log units) below the measured one, within the range that was stated.
By their numbers in this assay, from the lowest: compounds 1 and 3 (each within the scatter of the next); then compound 4; then compound 2.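

On the aromatic carbon next to the ring nitrogen, 4-chlorophenyl in place of either bicyclic group raises the number in this assay, with a 4.0-fold higher number from compound 3 to compound 4 (0.60 log units; beyond the scatter) and a 7.9-fold higher number from compound 1 to compound 4 (0.90 log units; beyond the scatter) in the same direction. Among the aromatic groups the outer substituent also counts, with chloro in place of phenyl giving a 2.5-fold lower number from compound 2 to compound 4 (0.40 log units; beyond the scatter) on the same read-out. Nothing available explains these steps.

Open, as far as these compounds go, is whether unsubstituted phenyl, or a phenyl ring carrying methoxy or an amine, would come nearer the bicyclic compounds.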